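A few compounds are considered here, and "the series" means these few. Any claim that something is new, unique, unknown or untested is made for them only; others in the source may bear on it.

Working notes on the series. Compound 1 `CCN(Cc1c[nH]nn1)C(=O)COc1ccc(C)cc1` and compound 2 `CCN(Cc1cccnc1)C(=O)COc1ccc(C)cc1` share one core and differ only in the heteroaryl group carried on the saturated chain carbon bound to the amide-type nitrogen. In an assay on HEK293 cells for agonist activity at transient receptor potential cation channel subfamily M member 8 (Homo sapiens), read by fluorescence and calcium flux, with a stated time of 15 min (a higher number here means that more compound is needed for the effect, a lower number that less compound is needed), compound 1 gives 31100 nM, and compound 2 gives 15400 nM. For the measured compounds named here, the single step measured so far, a 2.0-fold lower number from compound 1 to compound 2 (0.31 log units; beyond the scatter), is a modest one. Going by the values given here, on these two numbers compound 2 stands lowest, with compound 1 as its only neighbour.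

Compound 3 `CCN(Cc1ccco1)C(=O)COc1ccc(C)cc1` is not yet measured in this assay. It differs from compound 2 by furan-2-yl in place of pyridin-3-yl on a saturated chain carbon bound to an amide-type nitrogen. Among the compounds with values here, the one step that bears on it is the same kind of exchange at the same place, from compound 1 to compound 2, and that step was modest. Within the data shown here, no other measured pair informs the direction of a swap to furan-2-yl. The step from compound 2 to compound 3 in this assay is therefore expected to be small, a 1.0-fold higher number from compound 2 to compound 3 (0.02 log units; within the scatter), with no strong reason to expect it beyond the scatter in either direction. Compound 3 is estimated at 16000 nM in this assay, in a range from 5500 nM to 46000 nM.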

Compound 3, half-maximal effective concentration: 489 nM
For compound 3 the middle estimate is 33-fold (1.51 log units) above the measured one, and the stated range ends above it.
By their numbers in this assay, from the lowest: compound 3; then compound 2; then compound 1.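

The heteroaryl group on the saturated chain carbon bound to an amide-type nitrogen proves far more sensitive in this assay than the first exchange indicated, since the step of a 31-fold lower number from compound 2 to compound 3 (1.50 log units; beyond the scatter) is large, while the earlier step of a 2.0-fold lower number from compound 1 to compound 2 (0.31 log units; beyond the scatter) is modest. The step of a 64-fold lower number from compound 1 to compound 3 (1.80 log units; beyond the scatter) shows that a five-membered aromatic ring alone does not account for the low number, as compound 1 carries 1H-1,2,3-triazol-4-yl, also a five-membered ring, and has the highest number of the three, so compound 1 goes against any simple reading by ring size. No supporting data are available to explain this difference between furan-2-yl and the other two groups.

On these data alone, what remains open is which feature of furan-2-yl matters, as the three compounds do not separate the ring oxygen from the ring size or the point of attachment, which thiophen-2-yl, furan-3-yl or phenyl on the same carbon could address. They also leave open whether the low number persists when a longer chain replaces the ethyl group on the amide-type nitrogen.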